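The compounds below may be only part of what the source reports. "The series", "measured", "known", "first", "only" and "open" are said of these compounds alone.

Compound 1 `Nc1nc(C(F)(F)F)cc2c1[nH]c(=O)n2Cc1ccc(NCc2ccccc2)nc1` is one of two compounds with a number in an in vitro ADME assay on microsomes from liver (Rattus norvegicus) for pharmacokinetics; a lower number here means slower removal, a higher number faster removal of the compound. In this assay compound 1 gives 16 mL.min-1.g-1, the higher of the two numbers, though its neighbour sits close by. Among the measured compounds shown here, compound 2 `CN(CCN1CCCCC1)c1ccc(Cn2c(=O)[nH]c3c(N)nc(C(F)(F)F)cc32)cn1` gives 13 mL.min-1.g-1, and the one measured step, a 1.2-fold lower number from compound 1 to compound 2 (0.09 log units; within the scatter), came from putting methyl(2-(piperidin-1-yl)ethyl)amino in place of benzylamino on an aromatic carbon. Compound 3 `Nc1nc(C(F)(F)F)cc2c1[nH]c(=O)n2Cc1ccc(NCCO)nc1` also differs from compound 1 at the benzylamino group, by hydroxymethyl in place of phenyl on a saturated chain carbon bound to a nitrogen on an aromatic ring. For the measured compounds named here, that earlier step is the only guide, and it stayed within the scatter, but it swapped the whole benzylamino group rather than the phenyl alone, so it bears on the new change only loosely. The expectation is therefore a step of a 1.5-fold lower number from compound 1 to compound 3 (0.16 log units; within the scatter), that is, no move beyond the scatter, with the estimate for compound 3 at 11 mL.min-1.g-1 and a range from 4 mL.min-1.g-1 to 28 mL.min-1.g-1.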

Compound 3, intrinsic clearance in microsomes: < 8.5 mL.min-1.g-1
Compound 3: only a limit was reported; the forecaster's own chance of this, stated with the estimate: 10%; at least 1.2-fold (0.11 log units) between middle value and limit.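

In this assay compound 3 gives < 8.5 mL.min-1.g-1, which is a limit of the assay and not a number. Hydroxymethyl in place of phenyl gives an at least 1.8-fold lower number from compound 1 to compound 3 (0.27 log units; that floor lies within the scatter), and (2-hydroxyethyl)amino in place of methyl(2-(piperidin-1-yl)ethyl)amino gives an at least 1.5-fold lower number from compound 2 to compound 3 (0.18 log units; that floor lies within the scatter). Both are floors, so the true steps may be larger, and they show what the earlier compounds did not: at this position the aromatic ring can leave without the number going up, though the exact value remains hidden: the limit of < 8.5 mL.min-1.g-1 in this assay, at which 1 of the 3 values shown sits.

As far as these compounds go, how far compound 3 really lies under its limit stays open, so neither step can be said to pass the scatter. Also open, from the compounds shown here alone, is whether a methoxymethyl group or a carboxylic acid in place of hydroxymethyl would give a similar number.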